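Hydroxyphenyl isomers on a shared core: working notes

This account rests on a few compounds, and the source may have more. Where it says the series, first, only, none or still open, it means among the compounds named here.

Measured compounds:
compound 1 `Oc1ccc(-c2cc(-c3ccc(O)cc3)nc(-c3ccc(O)cc3)c2)cc1`: 4270 nM
compound 2 `Oc1ccc(-c2cc(-c3ccc(O)cc3)nc(-c3ccccc3O)c2)cc1`: 50000 nM
compound 3 `Oc1ccc(-c2cc(-c3ccccc3O)nc(-c3ccccc3O)c2)cc1`: 18300 nM

In a functional assay on T47D cells (Homo sapiens) for cytotoxicity, read by CCK-8 assay, with a stated time of 4 days (a lower number here means a stronger inhibitor, a higher number a weaker inhibitor), compound 1 gives 4270 nM, the lowest number of the three; compound 3 sits nearer to it, compound 2 furthest. Compound 4 `Oc1ccc(-c2cc(-c3cccc(O)c3)cc(-c3ccc(O)cc3)n2)cc1` differs from compound 1 by 3-hydroxyphenyl in place of 4-hydroxyphenyl on an aromatic carbon, at the carbon opposite the ring nitrogen. The two measured steps both move a hydroxyl on one arm: a 12-fold higher number from compound 1 to compound 2 (1.07 log units; beyond the scatter), then a 2.7-fold lower number from compound 2 to compound 3 (0.44 log units; beyond the scatter). Neither involves 3-hydroxyphenyl, so their bearing is indirect, but both show that trading a 4-hydroxyphenyl group for an isomer raises the number, strongly the first time. A weakening step beyond the scatter is therefore expected for compound 4, smaller than that first one. Compound 4 is expected at 11000 nM, between 4000 nM and 30000 nM. This corresponds to an expected step of a 2.6-fold higher number from compound 1 to compound 4 (0.41 log units; beyond the scatter).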

Compound 4, half-maximal inhibitory concentration: 4070 nM
Beside the measured number, compound 4's estimate is 2.7-fold (0.43 log units) above it, within the range that was stated.
By their numbers in this assay, from the lowest: compounds 4 and 1 (each within the scatter of the next); then compound 3; then compound 2.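

In this assay, 3-hydroxyphenyl in place of 4-hydroxyphenyl at the carbon opposite the ring nitrogen gives a 1.0-fold lower number from compound 1 to compound 4 (0.02 log units; within the scatter), so this swap, unlike the earlier isomer swaps, produces no readable difference. At this position, the 4-hydroxyphenyl group of compound 1 can therefore be exchanged for this isomer without a measurable penalty. No measurement shown here explains this result.

From the compounds shown here alone, whether a hydroxyl is needed on this arm at all remains open. A 2-hydroxyphenyl, methoxyphenyl or aminophenyl group at this carbon would address that.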